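What One Chloro May Do to Compound 2

The compounds below may be only part of what the source reports. "The series", "measured", "known", "first", "only" and "open" are said of these compounds alone.

Of the compounds shown here, three sharing one core have been measured in a physicochemical assay for lipophilicity, using the shake flask method, in phosphate buffer, measured as octanol-water partition, with a stated time of 2 h, at pH 7.4, tested at 1 uM; on this read-out lower numbers stand for lower lipophilicity and higher numbers for higher lipophilicity. Compound 1 `O=C(c1ccc(-c2ccc(O[C@H]3O[C@H](CO)[C@@H](O)[C@H](O)[C@@H]3O)cc2)cc1)N1CCOCC1` gives 0.2, compound 3 `N#CNC(=O)c1ccc(-c2ccc(O[C@H]3O[C@H](CO)[C@@H](O)[C@H](O)[C@@H]3O)cc2)cc1` gives -1.1, and compound 2 `N#Cc1ccc(-c2ccc(O[C@H]3O[C@H](CO)[C@@H](O)[C@H](O)[C@@H]3O)cc2)cc1` gives 1.4, the highest of the three.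

Compound 4 `N#Cc1ccc(-c2ccc(O[C@H]3O[C@H](CO)[C@@H](O)[C@H](O)[C@@H]3O)c(Cl)c2)cc1` differs from compound 2 in one place: chloro in place of hydrogen on an aromatic carbon. A chloro stands in place of a hydrogen on an aromatic carbon, ortho to a large group and meta to a 4-cyanophenyl group.

The measured steps are all large: a number 1.20 log units higher from compound 1 to compound 2 (beyond the scatter), a number 1.30 log units lower from compound 1 to compound 3 (beyond the scatter) and a number 2.50 log units lower from compound 2 to compound 3 (beyond the scatter). Each of them exchanges a different group, however, and none adds a chloro. They show how far this assay can move across these compounds, but they give no direct size for this change.

The estimate therefore starts from compound 2 at 1.4. A modest rise is expected, a number 0.60 log units higher from compound 2 to compound 4 (beyond the scatter), smaller than any of the measured steps. For compound 4 the estimated value is 2, with an expected range from 1.6 to 2.4.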

Compound 4, distribution coefficient: 2.1
For compound 4 the middle estimate is 0.10 log units below the measured one, and the stated range covers the measured number.
By their numbers in this assay, from the lowest: compound 3; then compound 1; then compound 2; then compound 4.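

In this assay, chloro in place of hydrogen on an aromatic carbon, ortho to a large group and meta to a 4-cyanophenyl group, gives a number 0.70 log units higher from compound 2 to compound 4 (beyond the scatter) and gives this position its first measured step. The earlier steps shown here exchanged other groups and left this carbon bearing hydrogen, so they could not show that adding 1 heavy atom here moves the number by more than the usual scatter. No measurement shown bears on why the number rises. From the compounds shown here alone, whether a fluoro, a methyl or a methoxy on this same carbon would shift the number as far, and whether an amine or a carboxylic acid would shift it the other way, stays open. So does whether the same chloro would give a similar step on compound 1 or compound 3.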